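The source may report more compounds than this note shows. Statements on the series, on what has been measured and on what is new or still open speak of the compounds shown alone.

Measured so far, in a functional assay on D-38 cells (Homo sapiens) for cytotoxicity; on this read-out higher numbers stand for an effect only at larger amounts of compound and lower numbers for an effect already at smaller amounts:
compound 1, `N[C@H]1C[C@H](n2ccc(=O)[nH]c2=O)O[C@@H]1CO`, a limit of > 100 uM
compound 2, `NC1CC(n2cc(I)c(=O)[nH]c2=O)OC1CO`, a limit of > 100 uM

Compound 2 stands at the limit of this assay, one of the two values that sit there, (the limit of > 100 uM in this assay, at which 2 of the 2 values shown sit). Compound 3, `NC1CC(n2cc(Cl)c(=O)[nH]c2=O)OC1CO`, differs from it by chloro in place of iodo on an aromatic carbon. Among the measured compounds shown here, no step between measured compounds covers this change. The expected step is a step that the limit leaves unreadable from compound 2 to compound 3, none beyond the scatter. Compound 3 is therefore expected at 150 uM, most likely again as a limit, within 50 uM to 500 uM.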

Compound 3, concentration for half-maximal effect: > 100 uM
Compound 3 ended at the assay's limit; the forecaster's own chance of this, stated with the estimate: 80%; the middle value lies beyond the limit too.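

Among the compounds shown here, no step from compound 2 to compound 3 can be read in this assay, for both values are limits: the limit of > 100 uM in this assay, at which 3 of the 3 values shown sit. The compounds shown leave open whether chloro and iodo differ at all in this assay.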